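Three Limits and a Fourth Compound to Test

A few compounds are considered here, and "the series" means these few. Any claim that something is new, unique, unknown or untested is made for them only; others in the source may bear on it.

Compound 1, `COc1ccc(/C=C\c2cc(OC)c(OC)c(OC)c2)cc1OCc1ccc(CNC(C)(C)C(=O)O)cc1`, in an ADME assay on HEK293 cells (Homo sapiens) for cytotoxicity, read by CCK-8 assay, with a stated time of 48 h (a lower number here means a stronger inhibitor, a higher number a weaker inhibitor), gives > 50000 nM, a limit of the assay rather than a number.
Compound 2, `COc1ccc(/C=C\c2cc(OC)c(OC)c(OC)c2)cc1OCc1ccc(CN2CCCC[C@H]2C(=O)O)cc1`, in this assay gives > 50000 nM, again a limit.
Compound 3, `COc1ccc(/C=C\c2cc(OC)c(OC)c(OC)c2)cc1OCc1ccc(CNCCO)cc1`, in this assay gives > 50000 nM, again a limit.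

Compound 1 therefore stands only at a limit, and so do its two neighbours, because of the limit of > 50000 nM in this assay, at which 3 of the 3 values shown sit. The three measured steps, a step that the two limits leave unreadable from compound 1 to compound 2, a step that the two limits leave unreadable from compound 1 to compound 3 and a step that the two limits leave unreadable from compound 2 to compound 3, say nothing about size in either direction.

Compound 4 is `COc1ccc(/C=C\c2cc(OC)c(OC)c(OC)c2)cc1OCc1ccc(CN2CCCCC2C(=O)NCCN)cc1`. It differs from compound 1 in one place: 2-((2-aminoethyl)carbamoyl)piperidin-1-yl in place of (1-carboxy-1-methylethyl)amino on a saturated chain carbon bound to an aromatic carbon. Among the compounds with values here, all three measured steps bear on the same position on the shared core, yet none of them can be read, so no step in this assay beyond the scatter is expected in either direction. The estimate for compound 4 in this assay is 50000 nM, with a range from 20000 nM to 100000 nM. This expected estimate corresponds to a number no higher from compound 1 to compound 4 (the limit leaves the size open), and the assay is most likely to report only a limit again.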

Compound 4, half-maximal inhibitory concentration: > 50000 nM
Compound 4 ended at the assay's limit (the forecaster's own chance of this, stated with the estimate: 80%); the middle value lies on the limit itself.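

The steps linking compound 4 to compound 1, compound 2 and compound 3 cannot be read, because all four compounds stop at the same point: the limit of > 50000 nM in this assay, at which 4 of the 4 values shown sit. The compounds shown leave open what actual number each would give, and so whether changing the group on the saturated chain carbon alters the result in this assay at all.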